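Fluorine to Ester at the Chain End of Compound 2

The compounds below may be only part of what the source reports. "The series", "measured", "known", "first", "only" and "open" are said of these compounds alone.

Compound 1 `COc1ccc(F)cc1-c1cccc(-c2n[nH]c(=O)o2)c1`: in a functional assay on the whole organism (strain Wistar albino) for inhibition, with Rattus norvegicus as the target, read by paw edema, with stated times of 30 min and 2 h, at a dose of 10 mg/kg by the oral route (on this read-out higher numbers stand for more inhibition at the one dose given (going by the name of the read-out) and lower numbers for less inhibition), compound 1 gives 56%.
Compound 2 `COc1ccc(F)cc1-c1cccc(-c2nn(CCCCF)c(=O)o2)c1`: in this assay compound 2 gives 83%.
Compound 3 `COc1ccc(F)cc1-c1cccc(-c2nn(CCOC3CCCCO3)c(=O)o2)c1`: in this assay compound 3 gives 56%.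

Compound 2 holds the highest of the three numbers; its steps to compound 1 and to compound 3 are both beyond the scatter. Compound 4 `COC(=O)CCCn1nc(-c2cccc(-c3cc(F)ccc3OC)c2)oc1=O` has not been measured. It differs from compound 2 by methoxycarbonyl in place of fluoromethyl on a saturated chain carbon, three bonds along the chain from an aromatic nitrogen.

Among the compounds with values here, two measured steps bear on this. Putting 4-fluorobutyl on the aromatic nitrogen gave a number 27 percentage points higher from compound 1 to compound 2 (beyond the scatter). Replacing 2-fluoroethyl at the chain end with (oxan-2-yl)oxy gave a number 27 percentage points lower from compound 2 to compound 3 (beyond the scatter), so that compound 3 sits where compound 1 does, as no change at the digits printed from compound 1 to compound 3 (within the scatter) shows. Both changes that removed the fluorine-bearing end brought the number back to the level of compound 1. Compound 4 likewise loses the fluorine and gains oxygen acceptors at the chain end, so a downward step is expected, of a number 21 percentage points lower from compound 2 to compound 4 (beyond the scatter). Compound 4 is therefore estimated at 62%, in the range 45% to 80%.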

Compound 4, a percentage reported as inhibition, in the whole organism at one dose (the size of the read-out at that dose, not a potency): 74%
Compound 4: the middle estimate sits 12 percentage points below what was measured; the range from low to high includes it.
By their numbers in this assay, from the lowest: compounds 1 and 3 (each within the scatter of the next); then compounds 4 and 2 (each within the scatter of the next).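

In this assay, the fluorine at the chain end proves not to be needed to stay close to compound 2: methoxycarbonyl in place of fluoromethyl gives a number 9 percentage points lower from compound 2 to compound 4 (within the scatter). The 3-(methoxycarbonyl)propyl chain also keeps a gain over hydrogen on the aromatic nitrogen, at a number 18 percentage points higher from compound 1 to compound 4 (beyond the scatter), and it differs from the chain ending in (oxan-2-yl)oxy by a number 18 percentage points higher from compound 3 to compound 4 (beyond the scatter), so among these compounds the number depends on the chain and not merely on the nitrogen carrying a substituent. Nothing available explains why these chains differ.

As far as these compounds go, whether a carboxylic acid or an amine at the chain end, or a longer chain carrying the same ester, would keep this level remains open. From the compounds shown here alone, with one dose per compound, how these compounds rank in potency also remains open.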